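4-Chlorophenoxy in place of methylsulfanyl: an untested step

A few compounds are considered here, and "the series" means these few. Any claim that something is new, unique, unknown or untested is made for them only; others in the source may bear on it.

Three compounds have numbers in a functional assay for inhibition of sodium/hydrogen exchanger (Oryctolagus cuniculus); a higher number here means a weaker inhibitor, a lower number a stronger inhibitor. Compound 1 `CS(=O)(=O)c1cc(C(=O)N=C(N)N)c(F)cc1F` gives 630 nM, compound 2 `CSc1cc(C)c(C(=O)N=C(N)N)cc1S(C)(=O)=O` gives 6 nM, and compound 3 `CCc1cc(OC)c(S(C)(=O)=O)cc1C(=O)N=C(N)N` gives 30 nM. Compound 2 thus has the lowest number of the three, and its gaps to compound 3 and to compound 1 both lie beyond the scatter. Compound 4 `Cc1cc(Oc2ccc(Cl)cc2)c(S(C)(=O)=O)cc1C(=O)N=C(N)N` has not yet been measured. It differs from compound 2 in one place: 4-chlorophenoxy in place of methylsulfanyl on an aromatic carbon. Going by the values given here, no step between measured compounds shows the effect of such a change, so the expectation rests on compound 2 alone. The step of a 2.5-fold higher number from compound 2 to compound 4 (0.40 log units; beyond the scatter) is expected to be small, toward a somewhat higher number, hardly beyond the scatter. Compound 4 is therefore estimated at 15 nM, within 4 nM to 60 nM.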

Compound 4, half-maximal inhibitory concentration: 13 nM
Estimate against measurement, compound 4: 1.2-fold (0.06 log units) above, and the stated range covers the measured number.
By their numbers in this assay, from the lowest: compound 2; then compound 4; then compound 3; then compound 1.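

In this assay the position ortho to a methylsulfonyl group accepts 4-chlorophenoxy, with its six-membered aromatic ring of carbon only, in place of the much smaller methylsulfanyl, and the exchange gives a 2.2-fold higher number from compound 2 to compound 4 (0.34 log units; beyond the scatter), a modest step. Going by these compounds alone, a large aromatic substituent at this place therefore costs little on this core, which none of the earlier compounds could show. Nothing among the data explains the size of this step.

On these data alone, whether the chlorine contributes to the number of compound 4 remains open. So does how a plain phenoxy group or a piperidine amine would read at this position.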